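Dropping a Chloro Group from a Trifluoromethyl Benzamide

The compounds below may be only part of what the source reports. "The series", "measured", "known", "first", "only" and "open" are said of these compounds alone.

Compound 2 `COc1cc(-c2nn(-c3cccc(NC(=O)c4ccc(Cl)c(C(F)(F)F)c4)c3)cc2-c2ccncc2)ccc1Cl` and compound 1 `O=C(Nc1cccc(-n2cc(-c3ccncc3)c(-c3ccc(Cl)c(O)c3)n2)c1)Nc1ccc(Cl)c(Cl)c1` were both tested in a functional assay on KM12 cells (Homo sapiens) for inhibition, read by sulforhodamine B assay, with a stated time of 48 h; on this read-out lower numbers stand for stronger inhibition and higher numbers for weaker inhibition. In this assay compound 1 gives 1010 nM, while compound 2 gives 2060 nM, the higher of the two numbers and so the weaker inhibitor, by a margin beyond the usual scatter. Compound 3 `COc1cc(-c2nn(-c3cccc(NC(=O)c4cccc(C(F)(F)F)c4)c3)cc2-c2ccncc2)ccc1Cl` is compound 2 with a single change: hydrogen in place of chloro on an aromatic carbon. Among the compounds with values here, no measured pair shows what this change does here, so there is no precedent to lean on. The step of a 1.5-fold higher number from compound 2 to compound 3 (0.16 log units; within the scatter) is expected to be small, likely within the scatter. Compound 3 is therefore estimated at 3000 nM, in a range from 1200 nM to 8000 nM.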

Compound 3, half-maximal inhibitory concentration: 1660 nM
For compound 3 the middle estimate is 1.8-fold (0.26 log units) above the measured one, within the range that was stated.
By their numbers in this assay, from the lowest: compounds 1, 3 and 2 (each within the scatter of the next, the first and the last beyond it).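

Within the data shown here, replacing the chloro group ortho to the trifluoromethyl group with hydrogen gives a 1.2-fold lower number from compound 2 to compound 3 (0.09 log units; within the scatter) in this assay, the first measured pair for this swap. The 4-chloro-3-(trifluoromethyl)phenyl and 3-(trifluoromethyl)phenyl groups therefore cannot be told apart on this read-out, so inhibition at this level does not depend on this chlorine. Nothing measured here explains why. Still open, going by these compounds, is what an amine or a carboxylic acid on this same aromatic carbon would give, and whether taking away the trifluoromethyl group would be tolerated equally well.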